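Replacing the Hydroxyethyl Amide by a Morpholine Amide

The source may hold more compounds than are shown below. What is called first, only, known or untested is meant among the compounds shown, and "the series" means these compounds.

Of the compounds shown here, two sharing one core have been measured in a functional assay on a cell-free system (plasma, Oryctolagus cuniculus) for inhibition of platelet-activating factor acetylhydrolase (Homo sapiens), tested at 100 nM; on this read-out higher numbers stand for more inhibition at the one concentration tested (going by the name of the read-out) and lower numbers for less inhibition. Compound 1 `CCCCCCCCN(C)C(=O)Cn1cc(Cc2cnc(=O)n(CCO)c2)c(=O)nc1SCc1ccc(F)cc1` gives 36% in this assay. Among the compounds with values here, compound 2 `CCCCCCCCN(C)C(=O)Cn1cc(Cc2cnc(=O)n(CC(=O)NCCO)c2)c(=O)nc1SCc1ccc(F)cc1` gives 40%, and the step of a number 4 percentage points higher from compound 1 to compound 2 (within the scatter) is within the scatter, so compound 2 and compound 1 cannot be told apart on these numbers; compound 2 simply sits at one end of the pair, with compound 1 its only neighbour.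

Compound 3 `CCCCCCCCN(C)C(=O)Cn1cc(Cc2cnc(=O)n(CC(=O)N3CCOCC3)c2)c(=O)nc1SCc1ccc(F)cc1` is not yet measured. It differs from compound 2 in one place: morpholin-4-yl in place of (2-hydroxyethyl)amino on a carbonyl carbon. Within the data shown here, the only measured step, from compound 1 to compound 2, changed the same region of the molecule, turning hydroxymethyl into (2-hydroxyethyl)carbamoyl, and it produced no movement beyond the scatter. Among the measured compounds shown here, no step shows what exchanging the (2-hydroxyethyl)amino group for morpholin-4-yl on that carbonyl carbon does. For the measured compounds named here, with a single, flat step as the only guide, the step of a number 2 percentage points lower from compound 2 to compound 3 (within the scatter) is expected to stay within the scatter, in no particular direction. Compound 3 is therefore estimated at 38%, with a range from 24% to 52%.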

Compound 3, a percentage reported as inhibition, at one concentration (the size of the read-out at that concentration, not a potency): 36%
Compound 3: middle estimate off by 2 percentage points, on the high side, and the stated range covers the measured number.
By their numbers in this assay, from the lowest: compounds 1, 3 and 2 (each within the scatter of the next).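

In this assay, swapping the open (2-hydroxyethyl)amino group on the carbonyl carbon for morpholin-4-yl, one six-membered non-aromatic ring with 0 hydrogen-bond donors, gives a number 4 percentage points lower from compound 2 to compound 3 (within the scatter), so this exchange of chain for ring leaves no change that these numbers can resolve. Setting (morpholin-4-yl)carbonyl in place of hydroxymethyl on the saturated chain carbon bound to an aromatic nitrogen gives no change at the digits printed from compound 1 to compound 3 (within the scatter), so the three compounds cannot be told apart on this read-out, even though the groups at this place now differ in size, in ring content and in hydrogen-bond donors. No independent measurement is available to explain why the numbers stay this close.

As far as these compounds go, it remains open whether a group of another kind on this carbonyl carbon, such as a carboxylic acid, a piperazin-1-yl ring bearing a free amine or a longer chain, would carry the number beyond the scatter. With only one concentration read, these values also leave open whether the three compounds would still be indistinguishable in a full concentration-response measurement.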